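The source may hold more compounds than are shown below. What is called first, only, known or untested is meant among the compounds shown, and "the series" means these compounds.

Measured in an in vitro ADME assay on microsomes from liver (Homo sapiens) for metabolic stability, read by HPLC; on this read-out lower numbers stand for slow clearance and higher numbers for fast clearance:
- compound 1 `NC(=O)[C@@H](CCC(F)(F)F)N(CC1COC1)S(=O)(=O)c1ccc(Cl)cc1`: 16.9 mL/min/kg
- compound 2 `NC(=O)[C@@H](CCC(F)(F)F)N(CC1CCCC1)S(=O)(=O)c1ccc(Cl)cc1`: 229 mL/min/kg
- compound 3 `NC(=O)[C@@H](CCC(F)(F)F)N(CC1CCOCC1)S(=O)(=O)c1ccc(Cl)cc1`: 114 mL/min/kg

Compound 3, at 114 mL/min/kg, cannot be told apart from compound 2, since the gap is a 2.0-fold lower number from compound 2 to compound 3 (0.30 log units; within the scatter). It stands clearly apart from compound 1, with a 6.7-fold higher number from compound 1 to compound 3 (0.83 log units; beyond the scatter).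

The next structure is compound 4 `NC(=O)[C@@H](CCC(F)(F)F)N(C[C@@H]1CCOC1)S(=O)(=O)c1ccc(Cl)cc1`, and the change is oxolan-3-yl in place of oxan-4-yl on a saturated chain carbon bound to a sulfonamide nitrogen. In words, oxolan-3-yl takes the place of oxan-4-yl on a saturated chain carbon bound to a sulfonamide nitrogen.

For the measured compounds named here, two measured steps bear most directly on this. One is the modest 6.7-fold higher number from compound 1 to compound 3 (0.83 log units; beyond the scatter), which joins the two compounds that carry an oxygen-containing ring. The other is the large 14-fold higher number from compound 1 to compound 2 (1.13 log units; beyond the scatter), which shows how far this position can move the number. Oxolan-3-yl is a smaller ring than oxan-4-yl but a larger one than the oxetan-3-yl of compound 1, so compound 4 is expected to fall somewhere inside the span set by a 6.7-fold higher number from compound 1 to compound 3 (0.83 log units; beyond the scatter). Going by the values given here, no measured compound carries this ring, so the expectation is loose. The estimated step is a 2.3-fold lower number from compound 3 to compound 4 (0.36 log units; beyond the scatter), towards slower clearance.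

For compound 4 the estimated value is 50 mL/min/kg, with an expected range of 22 mL/min/kg to 110 mL/min/kg.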

Compound 4, clearance: 69.8 mL/min/kg
Beside the measured number, compound 4's estimate is 1.4-fold (0.14 log units) below it; measured number inside the range.
By their numbers in this assay, from the lowest: compound 1; then compounds 4, 3 and 2 (each within the scatter of the next, the first and the last beyond it).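

In this assay, going from the six-membered oxan-4-yl to the five-membered oxolan-3-yl on a saturated chain carbon bound to a sulfonamide nitrogen gives no readable change (a 1.6-fold lower number from compound 3 to compound 4 (0.21 log units; within the scatter)). Even so, compound 4 stands clearly apart from both ends of the series (a 3.3-fold lower number from compound 2 to compound 4 (0.52 log units; beyond the scatter); a 4.1-fold higher number from compound 1 to compound 4 (0.62 log units; beyond the scatter)), whereas compound 3 cannot be told apart from compound 2. Compound 1 therefore remains alone at the low end, and an oxygen-containing ring at this position does not by itself bring the number down to that of oxetan-3-yl, while the data shown offer no measured explanation for these differences.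

The compounds shown leave open whether the opposite configuration at the defined stereocentre of oxolan-3-yl would give the same reading, as only one form of this ring appears here. They also leave open whether the low number of compound 1 depends on the ring oxygen or would persist with a ring amine such as azetidin-3-yl, or with an open ether chain such as 2-methoxyethyl, at the same place.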